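One Shared Change, Seen Twice in a Cytotoxicity Series

The source may hold more compounds than are shown below. What is called first, only, known or untested is meant among the compounds shown, and "the series" means these compounds.

Measured compounds:
Compound 1, `COc1cc(/C=C/C(=O)C2=C(/C=C/c3ccc(O)c(OC)c3)NC(=O)NC2c2ccc(C)cc2)ccc1O`, gives 100000 nM in a functional assay on HeLa cells (Homo sapiens) for cytotoxicity, read by MTT assay, with a stated time of 48 h; a lower number here means a stronger inhibitor, a higher number a weaker inhibitor.
Compound 2, `COc1cc(/C=C/C(=O)C2=C(/C=C/c3ccc(O)c(OC)c3)NC(=O)NC2c2ccccc2O)ccc1O`, gives 50000 nM in this assay.
Compound 3, `COc1cc(/C=C/C(=O)C2=C(/C=C/c3ccc(O)c(OC)c3)NC(=S)NC2c2ccc(C)cc2)ccc1O`, gives 25000 nM in this assay.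

The change from compound 1 to compound 2 is 2-hydroxyphenyl in place of 4-methylphenyl on a saturated ring carbon. The step it made was a 2.0-fold lower number from compound 1 to compound 2 (0.30 log units; within the scatter), which the scatter of the measurement could alone account for. Compound 3 has the lowest of the three numbers in this assay; how its core differs from the core of compound 1 is not broken down here.

Compound 4, `COc1cc(/C=C/C(=O)C2=C(/C=C/c3ccc(O)c(OC)c3)NC(=S)NC2c2ccccc2O)ccc1O`, is not yet measured. It differs from compound 3 by 2-hydroxyphenyl in place of 4-methylphenyl on a saturated ring carbon. The place of this change is the same, word for word, as for the earlier pair, so it is the same change. Because the earlier step was a 2.0-fold lower number from compound 1 to compound 2 (0.30 log units; within the scatter), a step of similar size is expected here, namely a 2.0-fold lower number from compound 3 to compound 4 (0.30 log units; within the scatter). Compound 4 is therefore estimated at 12500 nM in this assay, with a plausible span from 5000 nM to 40000 nM.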

Compound 4, half-maximal inhibitory concentration: 25000 nM
For compound 4 the middle estimate is 2.0-fold (0.30 log units) below the measured one, and the stated range covers the measured number.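

In this assay, putting 2-hydroxyphenyl in place of 4-methylphenyl on the saturated ring carbon gives no change at the digits printed from compound 3 to compound 4 (within the scatter). Set beside the earlier step, the two results agree, so the change behaves alike on these two cores as far as this measurement can tell: the same change on two cores in this assay, a 2.0-fold lower number (0.30 log units; within the scatter) from compound 1 to compound 2 and no change at the digits printed (within the scatter) from compound 3 to compound 4, 2.0-fold (0.30 log units) apart, within the scatter of two such steps. For the compounds shown here, this shows only that neither core gives a sign of a large effect from this change; it does not show that the change has a real effect on either core, and two pairs do not make a rule for the whole series.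

The compounds shown leave open whether a different group on the same saturated ring carbon, such as a phenyl ring carrying an amine or a carboxylic acid, would give a step that clearly exceeds the scatter. They also leave open whether 2-hydroxyphenyl in place of 4-methylphenyl would give a similar step on any core other than these two.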